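Pyrazolyl to Methoxy: Expecting a Modest Shift in Inhibition

The source may report more compounds than this note shows. Statements on the series, on what has been measured and on what is new or still open speak of the compounds shown alone.

Of the compounds shown here, three have so far been measured in a functional assay for inhibition of sodium/hydrogen exchanger (Oryctolagus cuniculus); on this read-out higher numbers stand for weaker inhibition and lower numbers for stronger inhibition. Compound 2 `CS(=O)(=O)c1cc(C(=O)N=C(N)N)ccc1-n1cccn1` gives 160 nM, the highest of the three numbers. Compound 1 `Cc1ccc(-c2ccc(C(=O)N=C(N)N)cc2S(C)(=O)=O)cc1` gives 100 nM, and a 1.6-fold higher number from compound 1 to compound 2 (0.20 log units; within the scatter). Compound 3 `Cc1cc(-n2cccn2)c(S(C)(=O)=O)cc1C(=O)N=C(N)N` gives 25 nM, and a 6.4-fold lower number from compound 2 to compound 3 (0.81 log units; beyond the scatter).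

Compound 4 `COc1ccc(C(=O)N=C(N)N)cc1S(C)(=O)=O` differs from compound 2 in one place: methoxy in place of 1H-pyrazol-1-yl on an aromatic carbon. Within the data shown here, no measured step swaps this ring for methoxy. The step from compound 1 to compound 2 replaced one ring with another and stayed within the scatter, while the step from compound 2 to compound 3 added a methyl elsewhere. The size of the coming step is therefore uncertain; a change within the scatter or a modest loss both seem plausible. Compound 4 is estimated at 400 nM, in a range from 120 nM to 1300 nM, meaning an expected 2.5-fold higher number from compound 2 to compound 4 (0.40 log units; beyond the scatter).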

Compound 4, half-maximal inhibitory concentration: 270 nM
For compound 4 the middle estimate is 1.5-fold (0.17 log units) above the measured one; measured number inside the range.
By their numbers in this assay, from the lowest: compound 3; then compounds 1, 2 and 4 (each within the scatter of the next, the first and the last beyond it).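

On this aromatic carbon, a ring is not needed to hold inhibition in this assay: methoxy in place of 1H-pyrazol-1-yl gives a 1.7-fold higher number from compound 2 to compound 4 (0.23 log units; within the scatter) and so stays within the scatter. Methoxy in place of 4-methylphenyl gives a 2.7-fold higher number from compound 1 to compound 4 (0.43 log units; beyond the scatter) and so is a modest loss of inhibition. No evidence is available to explain either step.

From the compounds shown here alone, whether an amine or a longer chain on this carbon would hold inhibition remains open. So does whether the added methyl that separates compound 3 from compound 2 would act the same way alongside methoxy.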